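A few compounds are considered here, and "the series" means these few. Any claim that something is new, unique, unknown or untested is made for them only; others in the source may bear on it.

Within the data shown here, in an ADME assay on liver for metabolic stability, with Liver microsome (Homo sapiens) as the target, using microsomes and NADPH, with a stated time of 30 min, tested at 0.5 uM (on this read-out lower numbers stand for slow clearance and higher numbers for fast clearance), compound 3 `Fc1ccc2c(c1)c(OCCn1ccnc1)nn2-c1ccccc1F` gives 150 mL/min/kg, the second highest of the three numbers measured so far. Its nearest neighbour is compound 2 `O=C(COc1nn(-c2ccccc2F)c2ccc(F)cc12)N1CCOCC1` with 117 mL/min/kg; the step of a 1.3-fold higher number from compound 2 to compound 3 (0.11 log units; within the scatter) stays within the scatter. Compound 1 `O=C1OCCN1CCOc1nn(-c2ccccc2F)c2ccc(F)cc12` gives 683 mL/min/kg, and the step of a 4.6-fold lower number from compound 1 to compound 3 (0.66 log units; beyond the scatter) lies beyond it. Compound 4 `O=c1[nH]ccn1CCOc1nn(-c2ccccc2F)c2ccc(F)cc12` has not yet been measured. It differs from compound 3 by a group of 6 heavy atoms (3 carbon, 2 nitrogen, 1 oxygen; one five-membered aromatic ring with 2 hetero atoms) in place of a group of 5 heavy atoms (3 carbon, 2 nitrogen; one five-membered aromatic ring with 2 hetero atoms), on a saturated chain carbon, two bonds along the chain from an oxygen on an aromatic ring. Among the measured compounds shown here, no measured step exchanges one five-membered aromatic ring for another, so the only guides are the modest steps of a 5.8-fold lower number from compound 1 to compound 2 (0.77 log units; beyond the scatter) and a 4.6-fold lower number from compound 1 to compound 3 (0.66 log units; beyond the scatter), which show that altering the group at this position shifts the read-out by a limited amount. A change of similar or smaller size is expected, in either direction. Compound 4 is therefore estimated at 170 mL/min/kg, between 80 mL/min/kg and 380 mL/min/kg, which would mean a 1.1-fold higher number from compound 3 to compound 4 (0.05 log units; within the scatter).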

Compound 4, clearance: 200 mL/min/kg
For compound 4 the middle estimate is 1.2-fold (0.07 log units) below the measured one, within the range that was stated.
By their numbers in this assay, from the lowest: compounds 2, 3 and 4 (each within the scatter of the next); then compound 1.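

In this assay, a second five-membered aromatic ring, this one carrying an oxygen, cannot be told apart from 1H-imidazol-1-yl on this chain (a 1.3-fold higher number from compound 3 to compound 4 (0.12 log units; within the scatter)). It also stays within the scatter of the (morpholin-4-yl)carbonyl compound (a 1.7-fold higher number from compound 2 to compound 4 (0.23 log units; within the scatter)), while the gap to the saturated 2-oxo-1,3-oxazolidin-3-yl ring remains beyond it (a 3.4-fold lower number from compound 1 to compound 4 (0.53 log units; beyond the scatter)). Among these four, compound 1 alone stands apart, with no compound going against this. Nothing measured here explains that gap.

On these data alone, whether an amine, a carboxylic acid or a longer chain at this place would group with compound 1 or with the other three stays open.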